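The compounds below may be only part of what the source reports. "The series", "measured", "known", "first", "only" and "open" are said of these compounds alone.

Compound 1: `C/C(=N\OCC(N)=O)c1ccc(Cl)c(Cl)c1` gives 55 mg/kg in a functional assay on the whole organism for inhibition, with Rattus norvegicus as the target, read by paw edema, with stated times of 1 h and 3 h; a higher number here means that more compound is needed for the effect, a lower number that less compound is needed.
Compound 2: `C/C(=C\CC(=O)O)c1ccc(Cl)cc1` gives 70 mg/kg in this assay.
Compound 3: `C/C(=N\OCCCC(=O)O)c1ccc(Cl)cc1` gives 58 mg/kg in this assay.

All three measured compounds share a chlorinated aryl unit carrying a short chain that ends in an acid or amide, and their numbers sit close together. Compound 3 differs from compound 1 and from compound 2 by less than the scatter of repeated measurements, so no ordering among the three can be read from these figures. Among the compounds with values here, the measured set therefore gives no step at all that could be used as a guide.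

Compound 4, `COC(=O)OCCO/N=C(\C)c1ccc(Cl)cc1`, has not been measured in this assay. Compared with compound 3 the change is (methoxycarbonyl)oxy in place of carboxymethyl on a saturated chain carbon, two bonds along the chain from an oxygen. The acid end of the chain is thus exchanged for a carbonate end, while the rest of the molecule is kept.

Nothing in the measured set shows how such an exchange affects the read-out. Since compound 1, with an amide end, and compound 2 and compound 3, with acid ends, all lie within the scatter of one another, compound 4 is expected to fall in the same region, with a step of a 1.2-fold higher number from compound 3 to compound 4 (0.08 log units; within the scatter) not exceeding the scatter. The value of compound 4 is estimated as 70 mg/kg, within a range from 35 mg/kg to 140 mg/kg.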

Compound 4, dose for half-maximal effect: 33 mg/kg
The estimate for compound 4 lay 2.1-fold (0.33 log units) above the measured number, outside the stated range (below it).
By their numbers in this assay, from the lowest: compounds 4, 1, 3 and 2 (each within the scatter of the next, the first and the last beyond it).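

In this assay, within the data shown here, the exchange of carboxymethyl for (methoxycarbonyl)oxy on a saturated chain carbon, two bonds along the chain from an oxygen, gives a 1.8-fold lower number from compound 3 to compound 4 (0.24 log units; within the scatter) and is the first single-place step in this set. It shows that, at this place, a chain end with 0 hydrogen-bond donors and 3 hydrogen-bond acceptors keeps the number within the scatter of the number for a chain end with 1 hydrogen-bond donor and 1 hydrogen-bond acceptor, so the carboxymethyl group is not needed for a read-out in this range. No measurement available here offers an explanation for this result.

The compounds shown leave open how other ends at this place would read, such as an amine, a hydroxyl group or a methyl ester, and how a longer chain carrying the same (methoxycarbonyl)oxy end would read. They also leave open whether a second chlorine on the aryl unit, as carried by compound 1, would shift the number when combined with this carbonate end.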